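A few compounds are considered here, and "the series" means these few. Any claim that something is new, unique, unknown or untested is made for them only; others in the source may bear on it.

Of the compounds shown here, three built on one shared core have been measured so far. In a functional assay on PC-3 cells (Homo sapiens) for cytotoxicity, read by MTT assay, with a stated time of 72 h (on this read-out higher numbers stand for weaker inhibition and lower numbers for stronger inhibition), compound 1 `CCCCCCCCNc1nc(SCc2ccc(C(F)(F)F)cc2)nc2ccccc12` gives 10500 nM. Compound 2 `CCOc1ccccc1Nc1nc(SCc2ccc(C(F)(F)F)cc2)nc2ccccc12` gives 26200 nM in this assay, and compound 3 `Cc1ccccc1Nc1nc(SCc2ccc(C(F)(F)F)cc2)nc2ccccc12` gives 36900 nM. On these numbers compound 2 stands second highest of the three: the step of a 2.5-fold higher number from compound 1 to compound 2 (0.40 log units; beyond the scatter) lies beyond the scatter, while the step of a 1.4-fold higher number from compound 2 to compound 3 (0.15 log units; within the scatter) lies within it, so compound 2 and compound 3 cannot be told apart.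

Compound 4 `CCOc1ccc(Nc2nc(SCc3ccc(C(F)(F)F)cc3)nc3ccccc23)cc1` has not yet been measured. It differs from compound 2 in one place: 4-ethoxyphenyl in place of 2-ethoxyphenyl on a nitrogen on an aromatic ring. The two compounds are made of the same atoms, joined differently.

Among the compounds with values here, none of the measured steps is of the same kind. The steps of a 2.5-fold higher number from compound 1 to compound 2 (0.40 log units; beyond the scatter) and a 3.5-fold higher number from compound 1 to compound 3 (0.55 log units; beyond the scatter) replace octyl with an aromatic ring, and the step of a 1.4-fold higher number from compound 2 to compound 3 (0.15 log units; within the scatter) exchanges the group on that ring and stays within the scatter. Nothing here shows how 4-ethoxyphenyl compares with 2-ethoxyphenyl. The expected step of a 1.0-fold lower number from compound 2 to compound 4 (0.02 log units; within the scatter) is therefore none beyond the scatter, in either direction. Compound 4 is expected to give about 25000 nM in this assay, within a range from 10000 nM to 60000 nM.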

Compound 4, half-maximal inhibitory concentration: 32100 nM
The estimate for compound 4 lay 1.3-fold (0.11 log units) below the measured number; measured number inside the range.
By their numbers in this assay, from the lowest: compound 1; then compounds 2, 4 and 3 (each within the scatter of the next).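

Moving the ethoxy group, with 4-ethoxyphenyl in place of 2-ethoxyphenyl on a nitrogen on an aromatic ring, is the first change here that keeps the same atoms and alters only how they are joined, and in this assay it gives no separation (a 1.2-fold higher number from compound 2 to compound 4 (0.09 log units; within the scatter)), so these two placements of ethoxy cannot be told apart. Exchanging 2-methylphenyl for 4-ethoxyphenyl also leaves the numbers inseparable (a 1.1-fold lower number from compound 3 to compound 4 (0.06 log units; within the scatter)), whereas replacing octyl with 4-ethoxyphenyl goes beyond the scatter (a 3.1-fold higher number from compound 1 to compound 4 (0.49 log units; beyond the scatter)), so all three aromatic groups shown now give higher numbers than octyl, a modest gap in each case. No supporting data bear on why the placement of ethoxy makes no visible difference in this assay.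

The compounds shown leave open whether a different group on the aromatic ring, such as an amine or a carboxylic acid, would give a number that can be separated from this cluster. They also leave open whether a longer chain than octyl on the same nitrogen would move the number further in the direction of stronger inhibition.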